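This account rests on a few compounds, and the source may have more. Where it says the series, first, only, none or still open, it means among the compounds named here.

Of the compounds shown here, three built on one shared core have been tested in an assay on HEK293 cells for agonist activity at Toll-like receptor 8 (Homo sapiens), read by spectrophotometry; a lower number here means that less compound is needed, a higher number that more compound is needed for the effect. Compound 1 `CCCCNc1nc(N)nc(C)c1CCCCO` gives 1310 nM, compound 2 `CCCCCc1c(C)nc(N)nc1NCCCC` gives 1220 nM, and compound 3 `CCCCNc1nc(N)nc(C)c1CCCCCc1ccccc1` gives 830 nM. Compound 3 shows the lowest of the three numbers, yet the steps of a 1.6-fold lower number from compound 1 to compound 3 (0.20 log units; within the scatter) and a 1.5-fold lower number from compound 2 to compound 3 (0.17 log units; within the scatter) both lie within the scatter, so the three compounds cannot be placed in any order. Compound 4 `CCCCNc1nc(N)nc(C)c1CCCN1CCCC1` has not yet been measured. It differs from compound 3 in a single place: pyrrolidin-1-yl in place of phenethyl on a saturated chain carbon, three bonds along the chain from an aromatic carbon. Going by the values given here, no measured step repeats this exact change. The nearest comparison is the step from compound 2 to compound 3, in which the phenyl that compound 4 loses again was attached, and that step stayed within the scatter; the same holds for the step in which compound 1 became compound 3. Both point to a chain end that barely moves the read-out. In this assay the expected step is therefore a 1.3-fold higher number from compound 3 to compound 4 (0.12 log units; within the scatter), inside the scatter. Compound 4 is estimated at 1100 nM, with a range from 450 nM to 2700 nM.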

Compound 4, half-maximal effective concentration: 110 nM
The estimate for compound 4 lay 10-fold (1.00 log units) above the measured number; the whole stated range lies above it.
By their numbers in this assay, from the lowest: compound 4; then compounds 3, 2 and 1 (each within the scatter of the next).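

In this assay, the chain end at this position had seemed to matter little, but pyrrolidin-1-yl in place of phenethyl gives a 7.5-fold lower number from compound 3 to compound 4 (0.88 log units; beyond the scatter), and the same group gives an 11-fold lower number from compound 2 to compound 4 (1.04 log units; beyond the scatter) and a 12-fold lower number from compound 1 to compound 4 (1.08 log units; beyond the scatter). So this position can influence the read-out after all: the chain ends ending in hydroxy, methyl and phenyl stay within the scatter of one another, and only compound 4, whose entering group holds a ring nitrogen, stands clearly apart. Nothing available explains this drop.

The compounds shown leave open whether the ring nitrogen or the ring as a whole goes with the lower number, which an open-chain diethylamino group or a cyclopentyl ring could separate. They also leave open whether a longer chain carrying the same pyrrolidine would keep it.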